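Removing a Pyrazole Methyl on Two Related Scaffolds

The source may hold more compounds than are shown below. What is called first, only, known or untested is meant among the compounds shown, and "the series" means these compounds.

Compound 1, `Cc1cnn(C(=O)N(C)CCN(C)Cc2cccc(OCc3ccccc3)c2)c1`, 9000 nM
Compound 2, `CN(CCN(C)C(=O)n1cccn1)Cc1cccc(OCc2ccccc2)c1`, 3000 nM
Compound 3, `Cc1cnn(C(=O)N(C)CCN(C)C(c2ccc(OCc3ccccc3)cc2)c2ccc(OCc3ccccc3)cc2)c1`, > 1000000 nM

All three values come from an assay on membranes from brain for binding affinity to Fatty-acid amide hydrolase 1 (Mus musculus), read by fluorescence, with stated times of 1 h and 30 min; a higher number here means a weaker inhibitor, a lower number a stronger inhibitor. Compound 1 gives 9000 nM and compound 2 gives 3000 nM. Compound 3 gives only a limit of this assay, > 1000000 nM, not a number.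

Compound 1 and compound 2 share a core and differ in one place: hydrogen in place of methyl on an aromatic carbon. This change gives a 3.0-fold lower number from compound 1 to compound 2 (0.48 log units; beyond the scatter). Compound 3 has a larger core; the difference between the two cores is not broken down here. Compound 4, `CN(CCN(C)C(c1ccc(OCc2ccccc2)cc1)c1ccc(OCc2ccccc2)cc1)C(=O)n1cccn1`, has not yet been measured and differs from compound 3 by the same change, (hydrogen in place of methyl on an aromatic carbon), at the same place.

Compound 3 sits at the limit of > 1000000 nM in this assay, at which 1 of the 3 values shown sits. A step of the size seen from compound 1 to compound 2 would leave compound 4 far beyond any useful potency, so this assay will most likely again report only a limit. For compound 4 the expected step is a number no higher from compound 3 to compound 4 (the limit leaves the size open). This rests on compound 3 giving only a limit and on the modest size of a 3.0-fold lower number from compound 1 to compound 2 (0.48 log units; beyond the scatter). Compound 4 is therefore estimated at 1000000 nM, between 200000 nM and 5000000 nM.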

Compound 4, half-maximal inhibitory concentration: > 1000000 nM
Compound 4 ended at the assay's limit (the forecaster's own chance of this, stated with the estimate: 85%); the middle value sits exactly at the limit.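

Going by these compounds alone, compound 3 and compound 4 both give only a limit of the assay, so no step between them can be read: the limit of > 1000000 nM in this assay, at which 2 of the 4 values shown sit. The compounds shown leave open whether going from 4-methyl-1H-pyrazol-1-yl to 1H-pyrazol-1-yl changes the reading at all on the larger core, where the true values of both compounds lie past the limit.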